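Chloro to iodo swap across two cores

The source may hold more compounds than are shown below. What is called first, only, known or untested is meant among the compounds shown, and "the series" means these compounds.

Measured compounds in a functional assay on MDA-MB-231 cells (Homo sapiens) for cytotoxicity, read by MTT assay, with a stated time of 48 h; a lower number here means a stronger inhibitor, a higher number a weaker inhibitor:
Compound 1, `O=C(NCCCCC(c1ccc(F)cc1)c1ccc(F)cc1)Nc1ccc(Cl)cc1`: 7680 nM
Compound 2, `O=C(NCCCCC(c1ccc(F)cc1)c1ccc(F)cc1)Nc1ccc(I)cc1`: 11800 nM
Compound 3, `O=C(NCCCCN(c1ccc(F)cc1)c1ccc(F)cc1)Nc1ccc(Cl)cc1`: in this assay only a limit is obtained, > 20000 nM

Compound 1 and compound 2 share one core and differ by iodo in place of chloro on an aromatic carbon. The step in this assay is a 1.5-fold higher number from compound 1 to compound 2 (0.19 log units; within the scatter), so the two values cannot be told apart here.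

Compound 3 carries a different core; how it differs from compound 1 is not broken down here. Among the compounds with values here, compound 3 sits at the limit of this assay, and that limit is the only information on it: the limit of > 20000 nM in this assay, at which 1 of the 3 values shown sits.

Compound 4, `O=C(NCCCCN(c1ccc(F)cc1)c1ccc(F)cc1)Nc1ccc(I)cc1`, is still to be measured in this assay. It stands to compound 3 as compound 2 stands to compound 1: iodo in place of chloro on an aromatic carbon. The place of the change is described in the same words for both pairs, so this is the same change made on the second core.

The expected step is a step that the limit leaves unreadable from compound 3 to compound 4, resting on the measured step of a 1.5-fold higher number from compound 1 to compound 2 (0.19 log units; within the scatter), which lies within the scatter. Since compound 3 already sits at the limit, compound 4 is expected most likely to return only a limit as well. Compound 4 is expected to give about 30000 nM, with a range from 12000 nM to 80000 nM.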

Compound 4, half-maximal inhibitory concentration: > 20000 nM
Compound 4: no number, only a limit; the forecaster's own chance of this, stated with the estimate: 75%; the middle value lies beyond the limit too.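

In this assay compound 4 returns only a limit, > 20000 nM. Compound 3 also returns only a limit, > 20000 nM. Within the data shown here, no step from compound 3 to compound 4 can be read from these two limits. The compounds shown leave open where compound 3 and compound 4 would fall as numbers, and whether the iodo for chloro swap on this core matches the step seen on the core of compound 1.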